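The source may hold more compounds than are shown below. What is called first, only, known or untested is meant among the compounds shown, and "the series" means these compounds.

In a physicochemical assay for lipophilicity (a higher number here means a more lipophilic compound, a lower number a more polar compound), compound 1 `CCOc1ccccc1C1=NC(c2ccccc2)CO1` gives 4.22. This number lies within the scatter of the two other measured compounds, compound 2 `Cc1ccc(C2=NC(c3ccccc3)CO2)cc1` at 4.11 and compound 3 `Clc1ccc(C2=NC(c3ccccc3)CO2)cc1` at 4.48. Those two do stand apart, with a number 0.37 log units higher from compound 2 to compound 3 (beyond the scatter), a modest step beyond the scatter for chloro in place of methyl on an aromatic carbon.

The unmeasured compound 4 `Cc1ccccc1C1=NC(c2ccccc2)CO1` departs from compound 1 by methyl in place of ethoxy on an aromatic carbon, ortho to a large group. For the measured compounds named here, no measured step removes an ethoxy, so that single step bears on this change only loosely. Compound 2 also carries a methyl, though not at the same place, and its number sits within the scatter of that of compound 1. No shift beyond the scatter is therefore expected in this assay, and the estimated step is a number 0.07 log units lower from compound 1 to compound 4 (within the scatter). For compound 4 the expected value is 4.15, within an estimated range of 3.85 to 4.45.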

Compound 4, partition coefficient: 3.68
Beside the measured number, compound 4's estimate is 0.47 log units above it; measured number outside the range, below it.
By their numbers in this assay, from the lowest: compound 4; then compounds 2, 1 and 3 (each within the scatter of the next, the first and the last beyond it).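

Methyl in place of ethoxy on an aromatic carbon, ortho to a large group, gives in this assay a number 0.54 log units lower from compound 1 to compound 4 (beyond the scatter), so this place is not indifferent to the exchange. The one earlier step, chloro in place of methyl, said nothing about an ethoxy leaving, and this is the first step shown that removes one. No accompanying measurement gives a reason for the size of this step.

The compounds shown leave open whether a methoxy, a longer chain or an amine at this same place would stay close to compound 1 at 4.22 or to compound 4 at 3.68. They also leave open whether the same exchange gives a step of similar size elsewhere on that ring.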